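The compounds below may be only part of what the source reports. "The series", "measured", "known", "first", "only" and "open" are said of these compounds alone.

Compound 1 `COc1cccc(/C=C2\CCC/C(=C\c3ccccc3)C2=O)c1OC`: 33500 nM
Compound 2 `COc1cccc(/C=C2\CCC/C(=C\c3ccc([N+](=O)[O-])cc3)C2=O)c1OC`: < 10000 nM (a limit of the assay)

In an ADME assay on Vero cells (Chlorocebus sabaeus) for inhibition (on this read-out higher numbers stand for lower toxicity in this test and lower numbers for higher toxicity in this test), compound 1 gives a measured number, 33500 nM. For compound 2 the assay reports only a limit, < 10000 nM. Within the data shown here, the one measured change is an at least 3.3-fold lower number from compound 1 to compound 2 (0.52 log units; beyond the scatter), and it consists of nitro in place of hydrogen on an aromatic carbon.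

Compound 3 `COc1cc([N+](=O)[O-])ccc1/C=C1\CCC/C(=C\c2cccc(OC)c2OC)C1=O` has not yet been measured. It differs from compound 2 by methoxy in place of hydrogen on an aromatic carbon, ortho to a large group and meta to a nitro group. Among the measured compounds shown here, the data hold no measured step for adding a methoxy, so the only guide is indirect. Compound 3 keeps the nitro group that came with an at least 3.3-fold lower number from compound 1 to compound 2 (0.52 log units; beyond the scatter), and it is therefore expected to stay in the same region of this assay as compound 2, with no change beyond the scatter. The estimated step is a step that the limit leaves unreadable from compound 2 to compound 3. The expected value for compound 3 is 7000 nM, within an estimated range of 2500 nM to 20000 nM.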

Compound 3, half-maximal cytotoxic concentration: 120000 nM
The estimate for compound 3 lay 17-fold (1.23 log units) below the measured number, outside the stated range (above it).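

In this assay, methoxy in place of hydrogen on an aromatic carbon, ortho to a large group and meta to a nitro group, gives an at least 12-fold higher number from compound 2 to compound 3 (1.07 log units; beyond the scatter), so this position on the ring that carries the nitro group is far from silent: a single replacement of hydrogen there moves the read-out strongly towards lower toxicity in this test. Compound 3 still carries the nitro group, which shows that the presence of that group does not by itself hold a compound at a low number, and that the step seen on adding it cannot be carried over unchanged to a neighbouring compound. The number for compound 2 is a limit of the assay, so the step gives only a lower bound on the size of the change: the limit of < 10000 nM in this assay, at which 1 of the 3 values shown sits.

On these data alone, whether a hydroxyl, an amine or a longer chain such as ethoxy at this same position would shift the number in the same way remains open. As far as these compounds go, it is also open whether methoxy at this position would do the same on a ring without the nitro group.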